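The source may report more compounds than this note shows. Statements on the series, on what has been measured and on what is new or still open speak of the compounds shown alone.

Among the compounds with values here, in a functional assay on LNCaP cells (Homo sapiens) for cytotoxicity, read by MTT assay, with a stated time of 72 h (a lower number here means a stronger inhibitor, a higher number a weaker inhibitor), three compounds have numbers so far. Compound 1 (`CC1=C(/C=C/C(=O)/C=C/c2cccc([N+](=O)[O-])c2)C(C)(C)CCC1`) gives 2700 nM and compound 2 (`CC1=C(/C=C/C(=O)/C=C/c2ccccc2)C(C)(C)CCC1O`) gives 5800 nM while compound 3 (`CC1=C(/C=C/C(=O)/C=C/c2cccc(C)c2)C(C)(C)CCC1O`) gives 4100 nM and so lies within the scatter of both.

The next compound is compound 4 (`CC1=C(/C=C/C(=O)/C=C/c2cccc([N+](=O)[O-])c2)C(C)(C)CCC1O`), which has nitro in place of methyl on an aromatic carbon, meta to a large group (nitro in place of methyl on an aromatic carbon). Within the data shown here, the one measured step at this place is small: a 1.4-fold lower number from compound 2 to compound 3 (0.15 log units; within the scatter) for methyl in place of hydrogen on an aromatic carbon. That step says little about nitro itself, so the range must stay wide. Compound 1 also bears nitro on its aromatic ring, though its core differs, and its value of 2700 nM lies within the scatter of compound 3. No step beyond the scatter is therefore expected in this assay for this change, and the estimate is a small one (a 1.2-fold lower number from compound 3 to compound 4 (0.08 log units; within the scatter)). Compound 4 is expected at 3400 nM (estimated range 1700 nM to 6500 nM).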

Compound 4, half-maximal inhibitory concentration: 2000 nM
Compound 4: middle estimate off by 1.7-fold (0.23 log units), on the high side; low and high end bracket the measured number.
By their numbers in this assay, from the lowest: compounds 4, 1, 3 and 2 (each within the scatter of the next, the first and the last beyond it).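

In this assay, within the data shown here, nitro on the aromatic carbon gives the first steps at this position that lie beyond the scatter, both when it replaces methyl (a 2.1-fold lower number from compound 3 to compound 4 (0.31 log units; beyond the scatter)) and when it replaces hydrogen (a 2.9-fold lower number from compound 2 to compound 4 (0.46 log units; beyond the scatter)). Both steps are modest, but they show that this position can change the number when the group is nitro, which the small methyl step could not show. With nitro on the ring, hydroxy in place of hydrogen on the saturated ring carbon stays within the scatter (a 1.4-fold lower number from compound 1 to compound 4 (0.13 log units; within the scatter)), and no measurement here offers a reason for any of these steps.

On these data alone, only hydrogen, methyl and nitro can be compared at this position, so it remains open how an amine, a carboxylic acid or a methoxy group would read there. Also open, as far as these compounds go, is whether nitro would give a similar step on another carbon of the ring.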